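The source may report more compounds than this note shows. Statements on the series, on what has been measured and on what is new or still open speak of the compounds shown alone.

Measured in a functional assay on MCF7 cells (Homo sapiens) for inhibition, read by sulforhodamine B assay; a higher number here means a weaker inhibitor, a lower number a stronger inhibitor:
Compound 1 `CCCc1ccc(NC2=CC(=O)c3nc4n(c3C2=O)[C@H]2OC[C@@H](O)[C@H]2OC4)cc1`: 4660 nM
Compound 2 `O=C1C=C(Nc2ccccc2F)C(=O)c2c1nc1n2[C@H]2OC[C@@H](O)[C@H]2OC1`: 3640 nM
Compound 3 `O=C1C=C(NC2CCCC2)C(=O)c2c1nc1n2[C@H]2OC[C@@H](O)[C@H]2OC1`: > 16000 nM

Compound 3 has no exact number, only a limit of > 16000 nM, as recorded in the limit of > 16000 nM in this assay, at which 1 of the 3 values shown sits. Compound 4 `COc1ccccc1NC1=CC(=O)c2nc3n(c2C1=O)[C@H]1OC[C@@H](O)[C@H]1OC3` carries 2-methoxyphenyl in place of cyclopentyl on an amine nitrogen. The measured steps that bear on this change run in the opposite direction, an at least 3.4-fold higher number from compound 1 to compound 3 (0.53 log units; beyond the scatter) and an at least 4.3-fold higher number from compound 2 to compound 3 (0.64 log units; beyond the scatter), and both are beyond the scatter. By contrast, a 1.3-fold lower number from compound 1 to compound 2 (0.11 log units; within the scatter) lies within it. A modest fall in the number is therefore expected on leaving cyclopentyl, and the estimated step is an at least 4.0-fold lower number from compound 3 to compound 4 (0.60 log units; beyond the scatter). Compound 4 is estimated at 4000 nM, with an expected range of 1600 nM to 10000 nM.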

Compound 4, half-maximal inhibitory concentration: > 4000 nM
Compound 4 was reported as a limit; the forecaster's own chance of this, stated with the estimate: 10%; the middle value lies on the limit itself.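

In this assay compound 4 is recorded only as a limit, so the 2-methoxyphenyl group on this amine nitrogen gets no exact number: the limit of > 4000 nM in this assay, at which 1 of the 4 values shown sits. Methoxy in place of fluoro on an aromatic carbon gives an at least 1.0-fold higher number from compound 2 to compound 4 (0.04 log units; that floor lies within the scatter), so this floor does not separate the two compounds, though the true step could be larger. The steps linking compound 4 to compound 1 and compound 3 cannot be read.

On these data alone, whether compound 4 differs from compound 2 at all stays open. Also open, as far as these compounds go, is what a chloro or hydroxy group in place of methoxy on that aromatic carbon would give.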